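Phenyl in Place of Pyridin-2-yl on a Shared Core

The compounds below may be only part of what the source reports. "The series", "measured", "known", "first", "only" and "open" are said of these compounds alone.

Compound 1, `C=C1C[C@]23C[C@@]1(O)CC[C@H]2c1cc(Br)c(O)c(C)c1[C@@H]3Cn1cc(-c2ccc(C)cc2)nn1`: > 20000 nM
Compound 2, `C=C1C[C@]23C[C@@]1(O)CC[C@H]2c1cc(Br)c(O)c(C)c1[C@@H]3Cn1cc(-c2ccccn2)nn1`: > 20000 nM

Of the compounds shown here, two built on one core have been tested in a functional assay on HL-60 cells (Homo sapiens) for cytotoxicity, read by MTT assay, with a stated time of 4 days; a higher number here means a weaker inhibitor, a lower number a stronger inhibitor. Compound 1 gives > 20000 nM, which is a limit of the assay and not a number. Compound 2 gives > 20000 nM, likewise a limit. Among the compounds with values here, the only step between measured compounds, a step that the two limits leave unreadable from compound 1 to compound 2, therefore cannot be read, because both values sit at the limit of > 20000 nM in this assay, at which 2 of the 2 values shown sit. Within the data shown here, compound 2 thus stands at the limit of this assay, and the one further value shown, that of compound 1, is a limit as well.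

Compound 3, `C=C1C[C@]23C[C@@]1(O)CC[C@H]2c1cc(Br)c(O)c(C)c1[C@@H]3Cn1cc(-c2ccccc2)nn1`, differs from compound 2 in one place: phenyl in place of pyridin-2-yl on an aromatic carbon. Among the measured compounds shown here, the single measured step, from compound 1 to compound 2, bears on this change only loosely and is of unreadable size, so no step beyond the scatter can be expected in this assay. The step from compound 2 to compound 3 is expected to be a step that the limit leaves unreadable from compound 2 to compound 3. Compound 3 is estimated at 30000 nM, within a range of 10000 nM to 100000 nM, most likely reported again only as a limit.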

Compound 3, half-maximal inhibitory concentration: > 20000 nM
Compound 3 was reported as a limit; the forecaster's own chance of this, stated with the estimate: 85%; the middle value lies beyond the limit too.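

Compound 3 gives > 20000 nM in this assay, which is a limit of the assay and not a number. No step among compound 1, compound 2 and compound 3 can be read, as all their values stand at one limit: the limit of > 20000 nM in this assay, at which 3 of the 3 values shown sit.

The compounds shown leave open how 4-methylphenyl, pyridin-2-yl and phenyl on the shared core compare in this assay.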